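Fluoro in Place of Methyl Across Two Cores

The source may hold more compounds than are shown below. What is called first, only, known or untested is meant among the compounds shown, and "the series" means these compounds.

Of the compounds shown here, three have been measured in a functional assay on MCF7 cells (Homo sapiens) for inhibition, read by trypan blue exclusion, with a stated time of 3 days; a higher number here means a weaker inhibitor, a lower number a stronger inhibitor. Compound 1 `COc1cc(C(=O)c2cn(-c3ccccc3)cc2-c2ccc(C)cc2)cc(OC)c1OC` gives 280 nM, compound 2 `COc1cc(C(=O)c2cn(-c3ccccc3)cc2-c2ccc(F)cc2)cc(OC)c1OC` gives 78 nM, and compound 3 `COc1cc(C(=O)c2cn(-c3ccc(C)cc3)cc2-c2ccccc2)cc(OC)c1OC` gives 30 nM, the lowest number of the three. The step of a 3.6-fold lower number from compound 1 to compound 2 (0.56 log units; beyond the scatter) comes from the change (fluoro in place of methyl on an aromatic carbon). Compound 4 `COc1cc(C(=O)c2cn(-c3ccc(F)cc3)cc2-c2ccccc2)cc(OC)c1OC` carries the same change on the core of compound 3: fluoro in place of methyl on an aromatic carbon. The core of compound 1 and the core of compound 3 are built from the same atoms joined differently; that difference is not broken down here. The change is placed on a different ring in compound 4 than in compound 2, so a smaller step is expected for compound 4. The step of a 1.9-fold lower number from compound 3 to compound 4 (0.27 log units; within the scatter) is expected to keep the direction of the measured step but to be smaller. For compound 4 a value of 16 nM is estimated, between 6 nM and 40 nM.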

Compound 4, half-maximal inhibitory concentration: 15 nM
Estimate against measurement, compound 4: 1.1-fold (0.03 log units) above, within the range that was stated.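

In this assay, fluoro in place of methyl gives a 2.0-fold lower number from compound 3 to compound 4 (0.30 log units; within the scatter), so on the core of compound 3 the change alone cannot be told apart from repeat-measurement scatter. The sizes of the steps on the two cores do not differ beyond what scatter allows, so the data fit the change carrying over from one core to the other: the same change on two cores in this assay, a 3.6-fold lower number (0.56 log units; beyond the scatter) from compound 1 to compound 2 and a 2.0-fold lower number (0.30 log units; within the scatter) from compound 3 to compound 4, 1.8-fold (0.25 log units) apart, within the scatter of two such steps This does not show that the change has a real effect on the core of compound 3, and two cores cannot establish a rule for the series.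

The compounds shown leave open how an amine or a carboxylic acid would behave on that same aromatic carbon. They also leave open whether either group would give steps of similar size on both cores.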